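Dropping the oxygen-bound chain from compound 1

The source may report more compounds than this note shows. Statements on the series, on what has been measured and on what is new or still open speak of the compounds shown alone.

In a functional assay on HeLa cells (Homo sapiens) for cytotoxicity, read by XTT assay, with a stated time of 72 h (a lower number here means a stronger inhibitor, a higher number a weaker inhibitor), compound 1 `CC(C)=CCC/C=C(\C)Cc1c(O)cc(O)c2c(=O)c(OC/C=C(\C)CCC=C(C)C)c(-c3ccc(O)cc3)oc12` gives 27000 nM and lies within the scatter of the other two measured compounds. Compound 2 `CC(C)=CCC/C=C(\C)Cc1c(OC/C=C(\C)CCC=C(C)C)c(C/C=C(\C)CCC=C(C)C)c(O)c2c(=O)cc(-c3ccccc3)oc12` gives 30000 nM here, and compound 3 `CC(C)=CCC/C(C)=C/COc1c(-c2ccc(O)cc2)oc2cc(O)cc(O)c2c1=O` gives 23000 nM here. Compound 4 `CC(C)=CCC/C=C(\C)Cc1c(O)cc(O)c2c(=O)c(O)c(-c3ccc(O)cc3)oc12` differs from compound 1 in one place: hydrogen in place of 3,7-dimethylocta-2,6-dien-1-yl on an oxygen on an aromatic ring means (3,7-dimethylocta-2,6-dien-1-yl)oxy becomes hydroxy. Among the measured compounds shown here, the only measured step that bears on this, a 1.2-fold lower number from compound 1 to compound 3 (0.07 log units; within the scatter), removes a chain from an aromatic carbon, not from an oxygen. No measurement covers the oxygen change itself. No step beyond the scatter is therefore expected in this assay, the estimate being a 1.4-fold lower number from compound 1 to compound 4 (0.13 log units; within the scatter) at its middle. Compound 4 is expected at 20000 nM, with an estimated range of 8000 nM to 50000 nM in this read-out.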

Compound 4, half-maximal inhibitory concentration: 30000 nM
The estimate for compound 4 lay 1.5-fold (0.18 log units) below the measured number; measured number inside the range.
By their numbers in this assay, from the lowest: compounds 3, 1, 2 and 4 (each within the scatter of the next).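

In this assay, hydrogen in place of 3,7-dimethylocta-2,6-dien-1-yl on an oxygen on an aromatic ring gives no step beyond the scatter (a 1.1-fold higher number from compound 1 to compound 4 (0.05 log units; within the scatter)). Alongside the step for the chain on the aromatic carbon (a 1.2-fold lower number from compound 1 to compound 3 (0.07 log units; within the scatter)), this shows that compound 1 can lose either chain singly without a readable change. No supporting data explain this flat result.

Going by these compounds, whether any group on this oxygen moves the number remains open, for example a shorter chain or one ending in an amine or a carboxylic acid.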